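A few compounds are considered here, and "the series" means these few. Any claim that something is new, unique, unknown or untested is made for them only; others in the source may bear on it.

Two measured compounds set the scene. Compound 1 `CN(C(=O)c1ccccc1-c1ccccc1)C(C)(C)c1cc(C(F)(F)F)cc(C(F)(F)F)c1` and compound 2 `FC(F)(F)c1cc(CNCc2ccccc2-c2ccccc2)cc(C(F)(F)F)c1` were both tested in an assay on CHO cells for displacement of a labelled ligand from Substance-P receptor (Homo sapiens); on this read-out lower numbers stand for stronger inhibition and higher numbers for weaker inhibition. In this assay compound 1 gives 295 nM, and compound 2 gives 372 nM. Compound 1 has the lower of these two numbers, but the gap to compound 2 is within the scatter, so the two compounds cannot be told apart on these results.

The next compound, compound 3 `CC(C)(NC(=O)c1ccccc1-c1ccccc1)c1cc(C(F)(F)F)cc(C(F)(F)F)c1`, differs from compound 1 in a single place: hydrogen in place of methyl on an amide-type nitrogen. For the measured compounds named here, no measured pair shows this exact change, so there is no step to lean on. Removing the methyl is expected to weaken binding somewhat, giving an expected step of a 3.1-fold higher number from compound 1 to compound 3 (0.48 log units; beyond the scatter) in this assay. On that basis compound 3 is estimated at 900 nM, with a range from 250 nM to 3500 nM.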

Compound 3, inhibition constant: > 10000 nM
Compound 3 ended at the assay's limit; the forecaster's own chance of this, stated with the estimate: 10%; middle value at least 11-fold (1.04 log units) from the limit.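

On the amide-type nitrogen of compound 1, the methyl proves to matter far more than its single carbon might suggest: in this assay, hydrogen in its place gives an at least 33-fold higher number from compound 1 to compound 3 (1.53 log units; beyond the scatter). This is the first single-place step among the compounds shown, and it marks this nitrogen as a position where a very small change can have a large effect. Compound 3 reads > 10000 nM, which is a limit of the assay and not a number, so the step has a lower bound but no known full size: the limit of > 10000 nM in this assay, at which 1 of the 3 values shown sits.

Still open, as far as these compounds go, is whether methyl is specially suited to this nitrogen or whether an ethyl group or a longer chain would serve as well. It is also unknown whether the same change would have so large an effect on a different core.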